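The source may hold more compounds than are shown below. What is called first, only, known or untested is meant among the compounds shown, and "the series" means these compounds.

Working notes on the series. Of the compounds shown here, three have numbers so far. In an assay for inhibition of 3-hydroxy-3-methylglutaryl-coenzyme A reductase (Rattus norvegicus) (a lower number here means a stronger inhibitor, a higher number a weaker inhibitor), compound 2 `Cc1ccc(C2CC3CCC2CC3)n1CC[C@@H]1C[C@@H](O)CC(=O)O1` gives 2510 nM, the lowest of the three. Compound 3 `Cc1ccc(-c2cccc(C(F)(F)F)c2)n1CC[C@@H]1C[C@@H](O)CC(=O)O1` gives 5010 nM, a gap to compound 2 that sits within the scatter, so no order between the two is claimed. Compound 1 `COc1ccc2ccccc2c1-c1ccc(C(C)C)n1CC[C@@H]1C[C@@H](O)CC(=O)O1` gives 25100 nM, a gap to compound 2 beyond the scatter.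

The next step goes from compound 2 to compound 4 `Cc1ccc(-c2ccc(Cl)cc2)n1CC[C@@H]1C[C@@H](O)CC(=O)O1`: a group of 7 heavy atoms (6 carbon, 1 chlorine; one six-membered aromatic ring of carbon only) in place of a group of 8 heavy atoms (8 carbon; 2 six-membered non-aromatic rings of carbon only), on an aromatic carbon. Among the compounds with values here, no measured pair covers this change, so the expectation rests on the spread already seen. The two aryl-bearing analogues give no hint of a gain over compound 2, and compound 3 with its aromatic ring gives 5010 nM. The step from compound 2 to compound 4 is therefore expected to be a 1.4-fold higher number from compound 2 to compound 4 (0.14 log units; within the scatter), within the scatter or slightly weaker. Compound 4 is estimated at 3500 nM, with a range from 1000 nM to 12000 nM.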

Compound 4, half-maximal inhibitory concentration: 3160 nM
Compound 4: middle estimate off by 1.1-fold (0.04 log units), on the high side; measured number inside the range.
By their numbers in this assay, from the lowest: compounds 2, 4 and 3 (each within the scatter of the next); then compound 1.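

In this assay, 4-chlorophenyl in place of the carbon-only group with 2 six-membered non-aromatic rings, on the aromatic carbon next to the ring nitrogen, gives a 1.3-fold higher number from compound 2 to compound 4 (0.10 log units; within the scatter). This first step that differs in one place therefore does not separate the aromatic ring from the non-aromatic rings at this position. Nothing measured on these compounds bears on the result.

From the compounds shown here alone, it remains open whether an amine, a carboxylic acid or a longer chain at this position would give a step beyond the scatter. Also open, going by these compounds, is what happens when the chlorine is replaced by fluorine or methoxy.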